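One More Chain Link: Expected Cytotoxicity of Compound 4

The source may report more compounds than this note shows. Statements on the series, on what has been measured and on what is new or still open speak of the compounds shown alone.

Compound 1, `N=C(N)c1ccc2oc(-c3cccc(OCCCCOc4ccccc4)c3)cc2c1`: 8100 nM
Compound 2, `CC(C)NC(=N)c1ccc2cc(-c3cccc(OCCCOc4ccccc4)c3)oc2c1`: 82300 nM
Compound 3, `c1ccc(OCCCOc2cccc(-c3cc4ccc(C5=NCCN5)cc4o3)c2)cc1`: 10100 nM

All three compounds were tested in an ADME assay on L6 cells (Rattus norvegicus) for cytotoxicity, read by resazurin assay, with a stated time of 70 h; on this read-out higher numbers stand for weaker inhibition and lower numbers for stronger inhibition. Compound 3 stands second highest of the three numbers. Its nearest neighbour is compound 1, whose value lies within the scatter of it; its furthest is compound 2, which lies beyond the scatter. Among the compounds with values here, the one clean comparison in the set is an 8.1-fold lower number from compound 2 to compound 3 (0.91 log units; beyond the scatter), and that step concerns the group on the aromatic carbon, not the chain that joins the two ring systems.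

Compound 4, `c1ccc(OCCCCOc2cccc(-c3cc4ccc(C5=NCCN5)cc4o3)c2)cc1`, has not yet been measured. It differs from compound 3 by phenoxymethyl in place of phenoxy on a saturated chain carbon, three bonds along the chain from an oxygen on an aromatic ring. Within the data shown here, no measured pair isolates this change. Compound 1 carries the same longer chain as compound 4, but it also carries a different group on the aromatic carbon, so it differs from compound 3 in two places and no single step can be read between them; what can be said is that the numbers of compound 1 and compound 3 sit within the scatter of one another. Among the measured compounds shown here, with no measured step bearing directly on the change, the expectation for compound 4 is no step beyond the scatter, a 1.0-fold lower number from compound 3 to compound 4 (0.00 log units; within the scatter). The estimate for compound 4 in this assay is 10000 nM, with a range from 4000 nM to 25000 nM.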

Compound 4, half-maximal inhibitory concentration: 5800 nM
Compound 4: the middle estimate sits 1.7-fold (0.24 log units) above what was measured; the measured number falls inside the stated range.
By their numbers in this assay, from the lowest: compounds 4, 1 and 3 (each within the scatter of the next); then compound 2.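

In this assay, the change from phenoxy to phenoxymethyl on this saturated chain carbon gives a 1.7-fold lower number from compound 3 to compound 4 (0.24 log units; within the scatter). Within the data shown here, this is the first pair in the set that differs only in this chain, and it shows that here the added chain link leaves the number within the ordinary spread of repeat measurements. Among these compounds, the only step beyond the scatter remains an 8.1-fold lower number from compound 2 to compound 3 (0.91 log units; beyond the scatter), which lies in the group on the aromatic carbon rather than in the chain, and nothing measured here offers an explanation for how either step turned out.

A single pair cannot show whether the chain stays this undemanding as it grows, so a longer chain, such as the 2-phenoxyethyl or 3-phenoxypropyl group at the same place, remains an open case. Also open, on these data alone, is whether the chain would tolerate a different kind of group, such as an amine or a carboxylic acid in place of the end phenoxy group, without the number moving beyond the scatter.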